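Aryl replacement at the amidine nitrogen of compound 1

The compounds below may be only part of what the source reports. "The series", "measured", "known", "first", "only" and "open" are said of these compounds alone.

Compound 1 `NS(=O)(=O)CC(=O)NCCSc1nonc1/C(=N/O)Nc1cccc(Br)c1` is the reference point for this step. In an assay for inhibition of Indoleamine 2,3-dioxygenase 1 (Homo sapiens), read by fluorescence, with a stated time of 24 h (on this read-out lower numbers stand for stronger inhibition and higher numbers for weaker inhibition), compound 1 gives 8.1 nM, the lowest of the three numbers measured, although both neighbours sit within the scatter of it. Compound 2 `CS(=O)(=O)NCCSc1nonc1/C(=N/O)Nc1ccc(F)c(Br)c1` gives 9.3 nM and compound 3 `CSc1nonc1/C(=N/O)Nc1ccc(F)c(Br)c1` gives 15 nM in this assay. For the measured compounds named here, the only single-point step among the measured compounds is a 1.6-fold higher number from compound 2 to compound 3 (0.21 log units; within the scatter), which concerns the chain on the sulfur and not the aryl group. Compound 1 and compound 2 differ in two places at once, so their two values can only be read side by side; they lie within the scatter of each other.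

Compound 4 `N#Cc1cc(N/C(=N\O)c2nonc2SCCNC(=O)CS(N)(=O)=O)ccc1F` carries 3-cyano-4-fluorophenyl in place of 3-bromophenyl on an amine nitrogen. Going by the values given here, no measured step changes the aryl group on the amine nitrogen, so nothing bears directly on this exchange; the one measured step, on the chain, stayed within the scatter. Among the compounds with values here, the series so far shows narrow spread across all three members, and the expectation is that this exchange also produces no step beyond the scatter, with the estimated step being a 1.2-fold higher number from compound 1 to compound 4 (0.09 log units; within the scatter). For compound 4 in this assay the estimate is 10 nM, with a range from 4 nM to 25 nM.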

Compound 4, half-maximal inhibitory concentration: 39 nM
Compound 4: middle estimate off by 3.9-fold (0.59 log units), on the low side; the measured number lies above the stated range.
By their numbers in this assay, from the lowest: compounds 1, 2 and 3 (each within the scatter of the next); then compound 4.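

In this assay, for the compounds shown here, 3-cyano-4-fluorophenyl in place of 3-bromophenyl on the amine nitrogen gives a 4.8-fold higher number from compound 1 to compound 4 (0.68 log units; beyond the scatter), the first step to pass beyond the scatter. The one earlier single-place step, on the chain at the sulfur, stayed within it (a 1.6-fold higher number from compound 2 to compound 3 (0.21 log units; within the scatter)), so the aryl group on this nitrogen is the first place shown where a single exchange moves the number, though the size of that move is modest and rests on one pair. The exchange removes the bromine and brings in a nitrile and a fluorine together, so the pair cannot assign the step to any one of these, and nothing measured on hand explains it.

Still open, from the compounds shown here alone, is whether a phenyl group carrying only the nitrile, or one with a chlorine or a methyl group where the bromine stands, would stay close to compound 1 or follow compound 4. Also open, going by these compounds, is whether the step holds on another chain at the sulfur, such as the plain methyl of compound 3, or is tied to the sulfonamide-bearing chain of compound 1.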